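Changing the aryl group on a shared nucleoside core

The source may hold more compounds than are shown below. What is called first, only, known or untested is meant among the compounds shown, and "the series" means these compounds.

Measured compounds:
compound 1, `OC[C@H]1O[C@@H](n2cnc3c(NCc4ccc(Cl)cc4)ncnc32)[C@H](O)[C@@H]1O`, giving 10200 nM
compound 2, `Cc1cccc(CNc2ncnc3c2ncn3[C@@H]2O[C@H](CO)[C@@H](O)[C@H]2O)c1`, giving 19100 nM
compound 3, `OC[C@H]1O[C@@H](n2cnc3c(NCc4ccc(F)c(Cl)c4)ncnc32)[C@H](O)[C@@H]1O`, giving 3400 nM

The three measured compounds share one core and differ only in the aryl group on a saturated chain carbon bound to a nitrogen on an aromatic ring. In a functional assay on CCRF-CEM cells (Homo sapiens) for antiproliferative activity, with a stated time of 72 h (a lower number here means a stronger inhibitor, a higher number a weaker inhibitor), compound 1 stands second highest of the three numbers. Its nearest neighbour is compound 2: a 1.9-fold higher number from compound 1 to compound 2 (0.27 log units; within the scatter). Its furthest is compound 3: a 3.0-fold lower number from compound 1 to compound 3 (0.48 log units; beyond the scatter). Between the other two, a 5.6-fold lower number from compound 2 to compound 3 (0.75 log units; beyond the scatter).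

Compound 4, `COc1cccc(CNc2ncnc3c2ncn3[C@@H]2O[C@H](CO)[C@@H](O)[C@H]2O)c1O`, has not yet been measured. It differs from compound 1 in one place: 2-hydroxy-3-methoxyphenyl in place of 4-chlorophenyl on a saturated chain carbon bound to a nitrogen on an aromatic ring. For the measured compounds named here, no measured step brings in a hydroxy or methoxy group, so the closest guides are the two exchanges at the same place starting from compound 1. Exchanging the chlorine-bearing ring for a methyl-bearing one gave a number within the scatter, while adding a second halogen gave a modest lower number. Going by the values given here, compound 4 loses the chlorine and gains two oxygen-bearing groups, for which no precedent exists here. Compound 4 is therefore expected to give about 15000 nM, within a range from 5000 nM to 50000 nM. This estimate means a 1.5-fold higher number from compound 1 to compound 4 (0.17 log units; within the scatter), a step expected to lie close to the scatter.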

Compound 4, half-maximal inhibitory concentration: 300 nM
Compound 4: the middle estimate sits 50-fold (1.70 log units) above what was measured; the measured number lies below the stated range.
By their numbers in this assay, from the lowest: compound 4; then compound 3; then compounds 1 and 2 (each within the scatter of the next).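

In this assay, for the compounds shown here, the aryl group on a saturated chain carbon bound to a nitrogen on an aromatic ring turns out to govern the number far more strongly than the earlier compounds suggested: their widest step was a 5.6-fold lower number from compound 2 to compound 3 (0.75 log units; beyond the scatter), whereas 2-hydroxy-3-methoxyphenyl gives a 34-fold lower number from compound 1 to compound 4 (1.53 log units; beyond the scatter), an 11-fold lower number from compound 3 to compound 4 (1.05 log units; beyond the scatter) and a 64-fold lower number from compound 2 to compound 4 (1.80 log units; beyond the scatter). Compound 4 therefore has the lowest number of the four, and it shows that a ring with no halogen can outdo the chlorine-bearing rings at this place, with hydrogen-bond donor and acceptors present that 4-chlorophenyl lacks. No measurement offered here explains why this exchange has so large an effect.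

The exchange brings in the hydroxy and methoxy groups together, so the compounds shown leave open whether either group alone on the phenyl ring would give a comparable number, or whether both are needed. Also open, going by these compounds, is how an amine or a carboxylic acid on the same ring would compare with compound 4 at this place on the shared core.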